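A few compounds are considered here, and "the series" means these few. Any claim that something is new, unique, unknown or untested is made for them only; others in the source may bear on it.

Going by the values given here, in an ADME assay on Vero cells (Chlorocebus sabaeus) for cytotoxicity, read by resazurin assay, with a stated time of 2 days (a lower number here means that less compound is tolerated, a higher number that more compound is tolerated), compound 1 (`CC(=O)OC[C@H]1O[C@@H](CC(=O)/C=C/c2cccc(NC(=O)Nc3ccccc3)c2)[C@H](OC(C)=O)[C@@H](OC(C)=O)[C@@H]1OC(C)=O`) gives 180000 nM and is the lower of the two numbers so far, with compound 2 (`COc1ccc(NC(=O)Nc2cccc(/C=C/C(=O)C[C@@H]3O[C@H](COC(C)=O)[C@@H](OC(C)=O)[C@H](OC(C)=O)[C@H]3OC(C)=O)c2)c([N+](=O)[O-])c1`) at 730000 nM as its nearest neighbour. Compound 3 (`CC(=O)O[C@@H]1[C@@H](OC(C)=O)[C@H](OC(C)=O)CO[C@H]1CC(=O)/C=C/c1cccc(NC(=O)Nc2ccccc2)c1`) has not yet been measured. It differs from compound 1 by hydrogen in place of acetoxymethyl on a saturated ring carbon. Among the compounds with values here, no measured pair shows acetoxymethyl leaving, so the data give no direct reading of this change. Within the data shown here, the only guide is one modest step beyond the scatter (a 4.1-fold higher number from compound 1 to compound 2 (0.61 log units; beyond the scatter)), with 4-methoxy-2-nitrophenyl in place of phenyl on an amide-type nitrogen, which is a different place in the molecule. Against that size, a step no larger is expected in this assay here, most likely none beyond the scatter, with no direction favoured. The estimate amounts to an expected 1.1-fold higher number from compound 1 to compound 3 (0.05 log units; within the scatter) and no more. For compound 3 the estimated value is 200000 nM with an expected range of 80000 nM to 500000 nM for the measurement.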

Compound 3, half-maximal cytotoxic concentration: 102000 nM
For compound 3 the middle estimate is 2.0-fold (0.29 log units) above the measured one; low and high end bracket the measured number.
By their numbers in this assay, from the lowest: compounds 3 and 1 (each within the scatter of the next); then compound 2.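

In this assay, going by these compounds alone, the step at this position is the first direct reading of hydrogen in place of acetoxymethyl on a saturated ring carbon, next to the ring oxygen (a 1.8-fold lower number from compound 1 to compound 3 (0.25 log units; within the scatter)). Within this pair, the loss of acetoxymethyl, with its 5 heavy atoms and no ring, therefore leaves the cytotoxicity reading within the scatter, whereas the only earlier step, made at an amide-type nitrogen in a different place, lies beyond it (a 4.1-fold higher number from compound 1 to compound 2 (0.61 log units; beyond the scatter)). No supporting measurement bears on this result, so it stands as an observation on a single pair.

The compounds shown leave open whether a hydroxymethyl group, a carboxylic acid or an aminomethyl group on the same ring carbon would also stay within the scatter of compound 1, since only acetoxymethyl and hydrogen have been compared there. They also leave open whether the same change, hydrogen in place of acetoxymethyl, would read the same way when 4-methoxy-2-nitrophenyl stands on the amide-type nitrogen, as it does in compound 2.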